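A Methoxy for a Methyl on a Silent Series

This account rests on a few compounds, and the source may have more. Where it says the series, first, only, none or still open, it means among the compounds named here.

Among the compounds with values here, compound 1 `Cc1ccc(Cn2ccc(Nc3cc(C)nc4nc(SCc5ccc(Br)cc5)nn34)n2)cc1` is one of three compounds measured in a functional assay on PC-9 cells (Homo sapiens) for inhibition, read by MTT assay, with a stated time of 72 h; a higher number here means a weaker inhibitor, a lower number a stronger inhibitor. In this assay compound 1 gives > 50000 nM, which is a limit of the assay and not a number. Compound 2 `CCCSc1nc2nc(C)cc(Nc3cc(-c4ccccc4)[nH]n3)n2n1` gives > 50000 nM in this assay, again a limit. Compound 3 `C#CCSc1nc2nc(C)cc(Nc3cc(-c4ccccc4)[nH]n3)n2n1` gives > 50000 nM in this assay, also a limit. The step that the two limits leave unreadable from compound 2 to compound 3 is consequently unreadable, and all three values sit at the limit of > 50000 nM in this assay, at which 3 of the 3 values shown sit, so compound 1 stands at the limit alongside the other two, with no readable difference among them.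

Compound 4 `COc1ccc(Cn2ccc(Nc3cc(C)nc4nc(SCc5ccc(Br)cc5)nn34)n2)cc1` differs from compound 1 in one place: methoxy in place of methyl on an aromatic carbon. Within the data shown here, no measured step in this assay bears directly on this change; the only measured step, a step that the two limits leave unreadable from compound 2 to compound 3, concerns a different part of the shared core and its size cannot be read. With every measured value at the limit, there is no ground to expect a step beyond the scatter in this assay in either direction.

Compound 4 is therefore expected to give about 70000 nM, within 20000 nM to 250000 nM, and most probably to be reported only as a limit. For compound 4 this estimate means an expected step that the limit leaves unreadable from compound 1 to compound 4.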

Compound 4, half-maximal inhibitory concentration: > 50000 nM
Compound 4: no number, only a limit (the forecaster's own chance of this, stated with the estimate: 85%); the middle value does not contradict the limit.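

No new step can be read from compound 1 to compound 4, since both are reported in this assay only as limits and not as numbers: the limit of > 50000 nM in this assay, at which 4 of the 4 values shown sit.

The compounds shown leave open how strongly any of them acts in this assay, and whether methoxy in place of methyl on the aromatic carbon changes that at all.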